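Urea series: chloro added to terminal phenyl

The source may report more compounds than this note shows. Statements on the series, on what has been measured and on what is new or still open speak of the compounds shown alone.

Measured so far:
compound 1 `CN(C)CCNc1nc(-c2ccc(NC(=O)Nc3ccc(F)cc3)cc2)nc2ccsc12` gives 540 nM
compound 2 `CN(C)CCNc1nc(-c2ccc(NC(=O)Nc3ccccc3Cl)cc2)nc2c(Cl)c(Cl)sc12` gives 1350 nM
compound 3 `CCN(CC)CCCNc1nc(-c2ccc(NC(=O)Nc3ccccc3)cc2)nc2c(Cl)c(Cl)sc12` gives 1780 nM

In a functional assay on MDA-MB-231 cells (Homo sapiens) for cytotoxicity, read by MTT assay, with a stated time of 72 h (on this read-out higher numbers stand for weaker inhibition and lower numbers for stronger inhibition), compound 3 holds the highest number of the three. Compound 2 sits close, its value within the scatter of that of compound 3; compound 1 sits beyond it, with the lowest number of the set. Compound 4 `CCN(CC)CCCNc1nc(-c2ccc(NC(=O)Nc3ccccc3Cl)cc2)nc2c(Cl)c(Cl)sc12` differs from compound 3 only by chloro in place of hydrogen on an aromatic carbon. Going by the values given here, no measured pair in this set isolates this change, and the other two compounds differ from compound 3 in more than one place, so no step size can be read off. The expected step of a 1.2-fold lower number from compound 3 to compound 4 (0.07 log units; within the scatter) is none beyond the scatter. Compound 4 is therefore estimated at 1500 nM, with a range from 700 nM to 3500 nM.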

Compound 4, half-maximal inhibitory concentration: 970 nM
The estimate for compound 4 lay 1.5-fold (0.19 log units) above the measured number, within the range that was stated.
By their numbers in this assay, from the lowest: compounds 1, 4, 2 and 3 (each within the scatter of the next, the first and the last beyond it).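

In this assay, going by these compounds alone, the change from phenyl to 2-chlorophenyl gives a 1.8-fold lower number from compound 3 to compound 4 (0.26 log units; within the scatter) and is the first reading of chloro on this aromatic carbon, with no separation beyond the scatter. The change to (diethylamino)methyl in place of dimethylamino gives a 1.4-fold lower number from compound 2 to compound 4 (0.14 log units; within the scatter) and also stays inside the scatter. No measurement at hand bears on the reason for either step.

As far as these compounds go, whether a trifluoromethyl or methoxy group at this place would move the number beyond the scatter remains open. So does the effect of a morpholine in place of the diethylamino group.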